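Aryl swap on the thiosemicarbazide series: compound 4

The compounds below may be only part of what the source reports. "The series", "measured", "known", "first", "only" and "open" are said of these compounds alone.

Measured in a functional assay on KB cells (Homo sapiens) for cytotoxicity, read by MTT assay, with a stated time of 72 h; on this read-out lower numbers stand for stronger inhibition and higher numbers for weaker inhibition:
compound 1 `COc1cc2ncnc(NNC(=S)NC(=O)c3ccccc3C)c2cc1OC` gives 11400 nM
compound 2 `COc1cc2ncnc(NNC(=S)NC(=O)c3ccc(F)cc3)c2cc1OC` gives 4530 nM
compound 3 `O=C(NC(=S)NNc1ncnc2ccccc12)c1cccc(Cl)c1` gives 4740 nM

Compound 2 has the lowest number of the three in this assay, but compound 3 sits within the scatter of it, so no order between those two can be claimed; only compound 1 stands clearly higher. Among the measured compounds shown here, the single step with one changed place, a 2.5-fold lower number from compound 1 to compound 2 (0.40 log units; beyond the scatter), shows that swapping the aryl group on the carbonyl carbon can move the read-out beyond the scatter.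

Compound 4 `COc1cc2ncnc(NNC(=S)NC(=O)c3cccc(Cl)c3)c2cc1OC` differs from compound 2 by 3-chlorophenyl in place of 4-fluorophenyl on a carbonyl carbon. For the measured compounds named here, no measured step covers this exact exchange. Going by the values given here, the one relevant comparison is compound 3, which carries the same 3-chlorophenyl on a different core and gives a number within the scatter of compound 2. On that basis no step beyond the scatter is expected, and compound 4 is estimated at 4500 nM in this assay, with a range of 2000 nM to 10000 nM. The expected step is a 1.0-fold lower number from compound 2 to compound 4 (0.00 log units; within the scatter).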

Compound 4, half-maximal inhibitory concentration: 4830 nM
Compound 4: the middle estimate sits 1.1-fold (0.03 log units) below what was measured; the measured number falls inside the stated range.
By their numbers in this assay, from the lowest: compounds 2, 3 and 4 (each within the scatter of the next); then compound 1.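

In this assay, a 1.1-fold higher number from compound 2 to compound 4 (0.03 log units; within the scatter), so with the shared core held fixed, 3-chlorophenyl and 4-fluorophenyl on this carbonyl carbon cannot be told apart. A second aryl group now also stands clear of 2-methylphenyl, with a 2.4-fold lower number from compound 1 to compound 4 (0.37 log units; beyond the scatter), so among the compounds sharing this core, compound 1 alone stands apart, and any trend at this position rests on that single compound. No measured evidence bearing on these numbers is available.

As far as these compounds go, whether the higher number of compound 1 follows the methyl group itself or its place on the ring stays open, and a 4-methylphenyl group on the same carbonyl carbon would separate those two readings. Also open, from the compounds shown here alone, is how an aryl group carrying an amine or a carboxylic acid would read here.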